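The source may hold more compounds than are shown below. What is called first, only, known or untested is meant among the compounds shown, and "the series" means these compounds.

Measured compounds in a functional assay on B16-F10 cells (Mus musculus) for inhibition, read by MTT assay, with a stated time of 72 h; on this read-out lower numbers stand for stronger inhibition and higher numbers for weaker inhibition:

- compound 1 `Cc1ccc(Nc2nc(SCc3cn(CC(=O)NC(=O)Nc4ccccn4)nn3)nc(-c3ccc(C)cc3)c2C#N)cc1`: 1010 nM
- compound 2 `Cc1ccc(Nc2nc(SCc3cn(CC(=O)NC(=O)Nc4ccccn4)nn3)nc(-c3ccc(Br)cc3)c2C#N)cc1`: 8160 nM
- compound 3 `CC(C)c1ccc(Nc2nc(SCc3cn(CC(=O)NC(=O)Nc4ccccn4)nn3)nc(-c3ccc(Cl)cc3)c2C#N)cc1`: 1590 nM

Compound 3 sits second highest of the three numbers in this assay. Its nearest neighbour is compound 1, whose number lies within the scatter of that of compound 3; compound 2 lies furthest off, beyond the scatter on the high side.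

Compound 4 `Cc1ccc(Nc2nc(SCc3cn(CC(=O)NC(=O)Nc4ccccn4)nn3)nc(-c3ccc(Cl)cc3)c2C#N)cc1` differs from compound 3 in one place: methyl in place of isopropyl on an aromatic carbon. The anilino ring thus becomes the same as in compound 1 and compound 2, while the chlorophenyl group of compound 3 is kept.

Among the compounds with values here, no measured step touches this position. Within the data shown here, the only step on record, an 8.1-fold higher number from compound 1 to compound 2 (0.91 log units; beyond the scatter), concerns the other aryl ring and offers no guide to the exchange of isopropyl for methyl. Compound 3 and compound 1, which differ at both rings, lie within the scatter of each other, so the combined effect of the two changes is small, but the two single contributions cannot be separated from the data.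

With nothing pointing either way, the step of a 1.1-fold lower number from compound 3 to compound 4 (0.03 log units; within the scatter) from compound 3 to compound 4 is expected to stay within the scatter. Compound 4 is therefore estimated at 1500 nM in this assay, with a range from 600 nM to 4500 nM.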

Compound 4, half-maximal inhibitory concentration: 1320 nM
Compound 4: middle estimate off by 1.1-fold (0.06 log units), on the high side; the range from low to high includes it.
By their numbers in this assay, from the lowest: compounds 1, 4 and 3 (each within the scatter of the next); then compound 2.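

Notes on the series: in this assay, replacing the (4-isopropylphenyl)amino group with the (4-methylphenyl)amino group while keeping the chlorophenyl group gives a 1.2-fold lower number from compound 3 to compound 4 (0.08 log units; within the scatter), so this first direct reading at the position shows no effect of the exchange that can be separated from the scatter. With the (4-methylphenyl)amino group held constant, the new compound also divides the substituents on the other aryl ring: chloro for methyl gives a 1.3-fold higher number from compound 1 to compound 4 (0.12 log units; within the scatter), and chloro for bromo gives a 6.2-fold lower number from compound 2 to compound 4 (0.79 log units; beyond the scatter), so among these three substituents only bromo stands apart, and the earlier gap between methyl and bromo is not a general feature of halogen in that place. No measurement at hand explains the separation of bromo from chloro and methyl.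

As far as these compounds go, the isopropyl to methyl exchange has been read only with chloro on the other ring, so it remains open whether it would behave the same way with bromo there. From the compounds shown here alone, it also remains open whether the position would accept an amine, a carboxylic acid or a longer chain as it accepts isopropyl and methyl.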